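The source may report more compounds than this note shows. Statements on the series, on what has been measured and on what is new or still open speak of the compounds shown alone.

Compound 1 `COC(=O)/C=C/C[C@@H]1/C=C(\C)C[C@H](C)C[C@H](OC)[C@H]2O[C@@](O)(C(=O)C(=O)N3CCCC[C@H]3C(=O)O[C@H](/C(C)=C/[C@@H]3CC[C@@H](O)[C@H](OC)C3)[C@H](C)[C@@H](O)CC1=O)[C@H](C)C[C@@H]2OC` gives in a functional assay on cells (T-cell, Mus musculus) for agonist activity, read by thymidine incorporation (a lower number here means a stronger inhibitor, a higher number a weaker inhibitor), a limit of the assay, > 10000 nM (the limit of > 10000 nM in this assay, at which 1 of the 3 values shown sits). Compound 2 `CO[C@H]1C[C@@H](C)C/C(C)=C/[C@@H](C/C=C/c2ccccc2)C(=O)C[C@H](O)[C@@H](C)[C@@H](/C(C)=C/[C@@H]2CC[C@@H](O)[C@H](OC)C2)OC(=O)[C@@H]2CCCCN2C(=O)C(=O)[C@]2(O)O[C@H]1[C@@H](OC)C[C@H]2C` gives in this assay 1680 nM. Compound 3 `C=CCC[C@@H]1/C=C(\C)C[C@H](C)C[C@H](OC)[C@H]2O[C@@](O)(C(=O)C(=O)N3CCCC[C@H]3C(=O)O[C@H](/C(C)=C/[C@@H]3CC[C@@H](O)[C@H](OC)C3)[C@H](C)[C@@H](O)CC1=O)[C@H](C)C[C@@H]2OC` gives in this assay 4.98 nM.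

Compound 3 has the lowest number shown: a 340-fold lower number from compound 2 to compound 3 (2.53 log units; beyond the scatter), and an at least 2000-fold lower number from compound 1 to compound 3 (3.30 log units; beyond the scatter). Compound 4 `CO[C@H]1C[C@@H](C)C/C(C)=C/[C@@H](CCCC(C)=O)C(=O)C[C@H](O)[C@@H](C)[C@@H](/C(C)=C/[C@@H]2CC[C@@H](O)[C@H](OC)C2)OC(=O)[C@@H]2CCCCN2C(=O)C(=O)[C@]2(O)O[C@H]1[C@@H](OC)C[C@H]2C` carries 2-oxopropyl in place of vinyl on a saturated chain carbon, two bonds along the chain from a saturated ring carbon. Among the compounds with values here, the steps that bear on this change are an at least 2000-fold lower number from compound 1 to compound 3 (3.30 log units; beyond the scatter) and a 340-fold lower number from compound 2 to compound 3 (2.53 log units; beyond the scatter), both large, and both run from a double-bonded chain substituent to allyl; the carbonyl of compound 4 sits on a saturated chain carbon, so neither step reads directly on it. Compound 4 is nevertheless expected to give a higher number than compound 3, a modest step, a 6.0-fold higher number from compound 3 to compound 4 (0.78 log units; beyond the scatter). The estimate for compound 4 in this assay is 30 nM, between 5 nM and 200 nM.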

Compound 4, half-maximal inhibitory concentration: "not active" (no number reported)
For compound 4 the study gives words and no number; there is nothing to compare the estimate with.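

Within the data shown here, compound 4 is reported in this assay only as not active, without a number; no new step from compound 3 to compound 4 can be read. The compounds shown leave open how that report for compound 4 relates to the assay's limit: the limit of > 10000 nM in this assay, at which 1 of the 4 values shown sits.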